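The source may report more compounds than this note shows. Statements on the series, on what has been measured and on what is new or still open speak of the compounds shown alone.

In a functional assay on NCI-N87 cells (Homo sapiens) for inhibition, read by CellTiter-Glo, with a stated time of 72 h (on this read-out lower numbers stand for stronger inhibition and higher numbers for weaker inhibition), compound 1 `Cc1cc(Nc2ncnc3cc(O)c(NC(=O)/C=C/[C@H]4CCCN4C)cc23)ccc1Oc1cnc2ccnn2c1` gives 1.9 nM while compound 2 `Cc1cc(Nc2ncnc3cc(O)c(NC(=O)/C=C/[C@H]4CCCN4C)cc23)ccc1Oc1cnn2cnnc2c1` gives 28.3 nM and so holds the higher of the two numbers. Compound 3 `Cc1cc(Nc2ncnc3cc(O)c(NC(=O)/C=C/[C@H]4CCCN4C)cc23)ccc1Oc1ccc2nccn2c1` keeps the shared core and differs from compound 2 only in the group on the oxygen: a group of 9 heavy atoms (7 carbon, 2 nitrogen; one five-membered aromatic ring with 2 hetero atoms, one six-membered aromatic ring with 1 hetero atom) in place of a group of 9 heavy atoms (5 carbon, 4 nitrogen; one five-membered aromatic ring with 3 hetero atoms, one six-membered aromatic ring with 2 hetero atoms), on an oxygen on an aromatic ring is the change. Going by the values given here, one measured step bears on it: a 15-fold higher number from compound 1 to compound 2 (1.17 log units; beyond the scatter) is large and beyond the scatter, and there the group with more nitrogen carried the higher number. Among the compounds with values here, the group entering compound 3 holds less nitrogen than either group measured so far, but no measured compound carries it, so this rests on a single step. A large step toward a lower number is therefore expected in this assay for this change. The expected step is a 5.7-fold lower number from compound 2 to compound 3 (0.75 log units; beyond the scatter) as a working figure. For compound 3 the estimated value is 5 nM with an expected range from 1.5 nM to 20 nM as its bounds.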

Compound 3, half-maximal inhibitory concentration: 4.08 nM
Compound 3: middle estimate off by 1.2-fold (0.09 log units), on the high side, and the stated range covers the measured number.
By their numbers in this assay, from the lowest: compound 1; then compound 3; then compound 2.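

In this assay, the group on the oxygen again sets the number: a 6.9-fold lower number from compound 2 to compound 3 (0.84 log units; beyond the scatter), so the group of 7 carbon, 2 nitrogen sits well clear of the group of 5 carbon, 4 nitrogen. The nitrogen count alone does not order the three compounds, however: a 2.1-fold higher number from compound 1 to compound 3 (0.33 log units; beyond the scatter), so compound 3, with the least nitrogen, goes against a simple trend of less nitrogen giving a lower number, and the arrangement of atoms within these groups may also matter. Nothing available explains these differences.

Still open, going by these compounds, is how a group on the oxygen carrying an amine, a methoxy or a carboxylic acid on its fused rings would read in this assay. Also open, on these data alone, is whether a single phenyl ring on the oxygen would keep the number near that of compound 1.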